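The source may report more compounds than this note shows. Statements on the series, on what has been measured and on what is new or still open speak of the compounds shown alone.

Compound 1 `Cc1ccc(-c2cc(N)n(-c3cccc(Cl)c3)n2)cc1`: > 100000 nM, a limit.
Compound 2 `Nc1cc(-c2ccc(Cl)cc2)nn1-c1cccc(Cl)c1`: > 100000 nM, a limit.
Compound 3 `CN(C)/C=N/c1cc(-c2ccc(Cl)cc2)nn1-c1cccc(Cl)c1`: 92700 nM.

All three compounds were tested in a functional assay on NPC-TW01 cells (Homo sapiens) for inhibition, read by MTT assay, with a stated time of 72 h; on this read-out lower numbers stand for stronger inhibition of growth and higher numbers for weaker inhibition of growth. Compound 2 gives no number there, only a limit. It stands at the limit of > 100000 nM in this assay, at which 2 of the 3 values shown sit, and compound 1 shares that position.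

The next compound, compound 4 `Nc1c(C=O)c(-c2ccc(Cl)cc2)nn1-c1cccc(Cl)c1`, keeps the core of compound 2 and carries formyl in place of hydrogen on an aromatic carbon. The counted change is as follows: formyl in place of hydrogen on an aromatic carbon.

Two measured steps are available, and neither was made at that carbon, so they bear on the change only indirectly. For the measured compounds named here, the first is a step that the two limits leave unreadable from compound 1 to compound 2, which gives no size to work from. The second is an at least 1.0-fold lower number from compound 2 to compound 3 (0.03 log units; that floor lies within the scatter). Going by the values given here, compound 3 is thus the only compound with a number, and its step from compound 2 shows nothing beyond the scatter.

Among the compounds with values here, with no measured step of real size to draw on, a large gain in growth inhibition is not expected, and a result close to the limit seems most likely. The expected change is an at least 1.2-fold lower number from compound 2 to compound 4 (0.09 log units; that floor lies within the scatter). For compound 4 the estimate is 80000 nM, with an expected range from 30000 nM to 200000 nM.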

Compound 4, concentration for 50% growth inhibition: > 100000 nM
Compound 4: a limit, no number; the forecaster's own chance of this, stated with the estimate: 50%; at least 1.2-fold (0.09 log units) between middle value and limit.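

In this assay compound 4 gives > 100000 nM, which is a limit and not a number. Compound 2 also sits at a limit, so no step can be read between compound 2 and compound 4: the limit of > 100000 nM in this assay, at which 3 of the 4 values shown sit.

The compounds shown leave open whether formyl in place of hydrogen on this aromatic carbon changes growth inhibition at all.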